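The compounds below may be only part of what the source reports. "The series", "measured", "known", "first", "only" and "open" are said of these compounds alone.

The series shares one core, seen in compound 1 `CNC(=O)c1ccc(Oc2cccc(NC(=S)Nc3ccc(C)cc3)c2)nc1` and compound 2 `CNC(=O)c1ccc(Oc2cccc(NC(=S)Nc3ccc(F)c(C(F)(F)F)c3)c2)nc1`. In a functional assay on HCT-116 cells (Homo sapiens) for antiproliferative activity, read by MTT assay (on this read-out lower numbers stand for stronger inhibition and higher numbers for weaker inhibition), compound 1 gives 53700 nM. In the same this assay compound 2 gives 19000 nM. Within the data shown here, compound 2 thus holds the lower of the two numbers measured so far, and compound 1 the higher one, by a margin that sits beyond the scatter. Among the measured compounds shown here, no single-point step between the two measured compounds can be drawn, since they differ in more than one place, so the comparison of compound 1 with compound 2 rests on the two values alone. The next compound, compound 3 `CNC(=O)c1ccc(Oc2cccc(NC(=S)Nc3ccc(F)c(Cl)c3)c2)nc1`, keeps the core of compound 2 and differs from it in one place: chloro in place of trifluoromethyl on an aromatic carbon. Nothing measured in the series covers this exact exchange, so the expectation for compound 3 rests on compound 2 alone. The step from compound 2 to compound 3 in this assay is expected to be small, a 1.3-fold higher number from compound 2 to compound 3 (0.12 log units; within the scatter), within the scatter, leaning if anything toward a slightly higher number. For compound 3 in this assay the estimate is 25000 nM, with a range from 8000 nM to 70000 nM.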

Compound 3, half-maximal inhibitory concentration: 25400 nM
Compound 3: the middle estimate sits 1.0-fold (0.01 log units) below what was measured, within the range that was stated.
By their numbers in this assay, from the lowest: compounds 2 and 3 (each within the scatter of the next); then compound 1.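

In this assay, chloro in place of trifluoromethyl on the aromatic carbon ortho to a fluoro group gives a 1.3-fold higher number from compound 2 to compound 3 (0.13 log units; within the scatter), so at this position the 4 heavy atoms of trifluoromethyl and the 1 heavy atom of chloro cannot be told apart on this read-out. The series also gains its first step on the whole aryl group, which the pair of compound 1 and compound 2 could not supply: 3-chloro-4-fluorophenyl in place of 4-methylphenyl on an amide-type nitrogen gives a 2.1-fold lower number from compound 1 to compound 3 (0.33 log units; beyond the scatter) as a modest change beyond the scatter. No measurement at hand accounts for either step.

Still open, as far as these compounds go, is whether a group of another kind on this aromatic carbon, such as an amine, a carboxylic acid or a methoxy group, stays level with chloro and trifluoromethyl in this assay or moves the number beyond the scatter. The compounds shown also leave open how far the step from 4-methylphenyl depends on the fluoro group, the chloro group or the two together.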